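Pyridine isomer swap at the aryl position of the core

The source may hold more compounds than are shown below. What is called first, only, known or untested is meant among the compounds shown, and "the series" means these compounds.

Measured compounds:
- compound 1, `CCN(c1ccc(C#N)c(Cl)c1)c1cc(-c2cccnc2)ccc1C`: 1270 nM
- compound 2, `CCN(c1ccc(C#N)c(Cl)c1)c1cc(-c2cn[nH]c2)ccc1C`: "not determined" (no result reported)
- compound 3, `CCN(c1ccc(C#N)c(Cl)c1)c1cc(-c2ccco2)ccc1C`: > 30000 nM

The series shares one core and varies only the aromatic group on the carbon ring. In a functional assay on VCaP cells (Homo sapiens) for antiproliferative activity, read by CCK-8 assay, with a stated time of 6 days (on this read-out higher numbers stand for weaker inhibition and lower numbers for stronger inhibition), compound 1 gives 1270 nM. For compound 2 no result was reported in this assay. Compound 3 sits at the limit of > 30000 nM in this assay, at which 1 of the 3 values shown sits, which is a limit of the assay rather than a number, so compound 3 stands at the weak end of what is known, with one further entry lacking any figure at all.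

Within the data shown here, the one fully measured step is an at least 23-fold higher number from compound 1 to compound 3 (1.37 log units; beyond the scatter), and it bears directly on the change to compound 4, `CCN(c1ccc(C#N)c(Cl)c1)c1cc(-c2ccncc2)ccc1C`, since that change is pyridin-4-yl in place of furan-2-yl on an aromatic carbon. It reverses the kind of move made from compound 1 to compound 3, returning a six-membered ring with one nitrogen to the place that carried furan-2-yl. The expectation is therefore a step back toward the value of compound 1, in the direction of stronger inhibition, and large in size, though pyridin-4-yl is not the same group as pyridin-3-yl and the recovery may be only partial. Compound 4 is estimated at 3000 nM, with a range from 800 nM to 20000 nM, which corresponds to an expected step of an at least 10-fold lower number from compound 3 to compound 4 (1.00 log units; beyond the scatter).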

Compound 4, half-maximal inhibitory concentration: 2900 nM
The estimate for compound 4 lay 1.0-fold (0.01 log units) above the measured number; low and high end bracket the measured number.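

Placing pyridin-4-yl where furan-2-yl stood gives an at least 10-fold lower number from compound 3 to compound 4 (1.01 log units; beyond the scatter) in this assay and so shows that the activity at this position is not confined to the pyridin-3-yl group of compound 1. Exchanging one pyridine for the other is a much smaller change than leaving the pyridines for the furan, with a 2.3-fold higher number from compound 1 to compound 4 (0.36 log units; beyond the scatter) as a modest step that still lies beyond the scatter, so the place of the ring nitrogen has a measurable but limited effect in these two compounds. The step from compound 3 can only be read as a minimum, as the value of compound 3 is a limit of the assay and not a number: the limit of > 30000 nM in this assay, at which 1 of the 4 values shown sits.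

What a plain phenyl ring or a pyridin-2-yl group would give on this aromatic carbon remains open, so the compounds shown cannot separate the presence of the ring nitrogen from the size of the ring. Going by these compounds, compound 2 has no result, its steps to the other compounds cannot be read, and how far compound 3 lies beyond its limit also stays unknown.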